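Shortening the Alkyl Chain in a Phosphate Dithiocarbamate Set

A few compounds are considered here, and "the series" means these few. Any claim that something is new, unique, unknown or untested is made for them only; others in the source may bear on it.

Compound 1 `CCCCCCOP(=O)(O)OCCSC(=S)N1CCCCCC1` gives 55000 nM in a functional assay on MCF7 cells (Homo sapiens) for inhibition, read by MTT assay, with stated times of 18 h and 4 h; on this read-out higher numbers stand for weaker inhibition and lower numbers for stronger inhibition.
Compound 2 `CCCCCCOP(=O)(O)OCCSC(=S)N1CCN(C)CC1` gives 58000 nM in this assay.
Compound 3 `CCCOP(=O)(O)OCCSC(=S)N1CCCCCC1` gives 74000 nM in this assay.

All three measured compounds fall close together, and none of their differences goes beyond the usual scatter. Compound 2 differs from compound 1 by 4-methylpiperazin-1-yl in place of azepan-1-yl on a thiocarbonyl carbon, and that change gave a 1.1-fold higher number from compound 1 to compound 2 (0.02 log units; within the scatter). Compound 3 differs from compound 1 by hydrogen in place of propyl on a saturated chain carbon, three bonds along the chain from an oxygen on an unsaturated carbon, and that change gave a 1.3-fold higher number from compound 1 to compound 3 (0.13 log units; within the scatter).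

Compound 4 `CCCOP(=O)(O)OCCSC(=S)N1CCN(C)CC1` has not yet been measured. It is related to compound 2 by hydrogen in place of propyl on a saturated chain carbon, three bonds along the chain from an oxygen on an unsaturated carbon, the same change that links compound 1 to compound 3, made on the other core. Since the move from compound 1 to compound 3 stayed within the scatter, the corresponding move is expected to be similarly small here: the estimated step is a 1.3-fold higher number from compound 2 to compound 4 (0.11 log units; within the scatter), because a 1.3-fold higher number from compound 1 to compound 3 (0.13 log units; within the scatter) shows how little the chain change mattered before. Compound 4 is therefore expected to give about 75000 nM in this assay. For compound 4 the expected range runs from 40000 nM to 140000 nM.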

Compound 4, half-maximal inhibitory concentration: 59000 nM
The estimate for compound 4 lay 1.3-fold (0.10 log units) above the measured number; measured number inside the range.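

In this assay, shortening the hexyl chain to propyl on the core of compound 2 gave a 1.0-fold higher number from compound 2 to compound 4 (0.01 log units; within the scatter). Set beside the same change on the core of compound 1, the two steps do not differ: the same change on two cores in this assay, a 1.3-fold higher number (0.13 log units; within the scatter) from compound 1 to compound 3 and a 1.0-fold higher number (0.01 log units; within the scatter) from compound 2 to compound 4, 1.3-fold (0.12 log units) apart, within the scatter of two such steps. This shows that on these two cores the change carries over as a step too small to tell apart from repeat-measurement noise, but it does not show that hexyl and propyl truly differ in this assay, nor that the change would stay this small on any other core.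

Only hexyl and propyl chains appear here, paired with azepan-1-yl and 4-methylpiperazin-1-yl groups, and every number falls within a narrow band, so these compounds do not reveal what could move the read-out clearly. As far as these compounds go, how a longer chain such as decyl, or a chain carrying an amine or a carboxylic acid, would read in this assay remains open.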